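Removing the chloro from a weak potassium channel activator

The source may report more compounds than this note shows. Statements on the series, on what has been measured and on what is new or still open speak of the compounds shown alone.

Measured so far:
compound 1, `CC1CCN(S(=O)(=O)N2CCN(CC(=O)Nc3ccc(F)cc3)CC2)CC1` — > 10000 nM
compound 2, `CC1CCN(S(=O)(=O)N2CCN(CC(=O)Nc3cc(Cl)ccc3F)CC2)CC1` — 3800 nM

In an assay on HEK293 cells for activation of potassium channel subfamily T member 1 (Homo sapiens), read by thallium flux (a higher number here means that more compound is needed for the effect, a lower number that less compound is needed), compound 1 reaches only (the limit of > 10000 nM in this assay, at which 1 of the 2 values shown sits), which is a limit of the assay and not a number. For the measured compounds named here, compound 2 is the only compound with a proper number, 3800 nM, and the step of an at least 2.6-fold lower number from compound 1 to compound 2 (0.42 log units; beyond the scatter) shows that the 5-chloro-2-fluorophenyl group brings the number down from the limit.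

Compound 3, `CC1CCN(S(=O)(=O)N2CCN(CC(=O)Nc3ccccc3F)CC2)CC1`, has not yet been measured. It differs from compound 2 by hydrogen in place of chloro on an aromatic carbon, meta to a large group and para to a fluoro group. Going by the values given here, only the step from compound 1 to compound 2 bears on this, and it points to the chloro as part of what made compound 2 better than compound 1. Removing it is therefore expected to raise the number, with the estimated step of a 2.1-fold higher number from compound 2 to compound 3 (0.32 log units; beyond the scatter). For compound 3 the estimate in this assay is 8000 nM, ranging from 3000 nM to 20000 nM.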

Compound 3, half-maximal effective concentration: > 10000 nM
Compound 3: no number, only a limit; the forecaster's own chance of this, stated with the estimate: 45%; middle value at least 1.2-fold (0.09 log units) from the limit.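

Taking away the single chlorine atom while the rest of the 2-fluorophenyl group stays in place gives an at least 2.6-fold higher number from compound 2 to compound 3 (0.42 log units; beyond the scatter) in this assay. The earlier step replaced 4-fluorophenyl with 5-chloro-2-fluorophenyl as a whole, so it could not separate the chloro from the change in the fluoro group; this step changes the chloro alone and shows that compound 2 depends on it for a readable number. The step between compound 1 and compound 3 cannot be read, as both of their values are limits: the limit of > 10000 nM in this assay, at which 2 of the 3 values shown sit.

As far as these compounds go, how large the rise really is stays open, with only a limit for compound 3. Also open, from the compounds shown here alone, is whether bromo, methyl or methoxy on the same aromatic carbon could match or improve on compound 2 at 3800 nM.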